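The source may hold more compounds than are shown below. What is called first, only, known or untested is meant among the compounds shown, and "the series" means these compounds.

Compound 1: `C=CC(=O)Nc1ccc(-c2nc(Cl)cc(Nc3ccc(C(=O)Nc4ccc(F)cc4)cc3)n2)cc1` — compound 1 gives "not determined" (no result reported) in a functional assay on Raji cells (Homo sapiens) for antiproliferative activity, read by MTT assay, with a stated time of 48 h; on this read-out higher numbers stand for weaker inhibition and lower numbers for stronger inhibition.
Compound 2: `C=CC(=O)Nc1ccc(-c2nc(Cl)cc(Nc3ccc(C(=O)Nc4cc(C(F)(F)F)cc(C(F)(F)F)c4)cc3)n2)cc1` — compound 2 gives 9360 nM in this assay.
Compound 3: `C=CC(=O)Nc1ccc(-c2nc(Cl)cc(Nc3ccc(C(=O)Nc4cc(C)ccc4C)cc3)n2)cc1` — compound 3 gives 20900 nM in this assay.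

Within the data shown here, only two numbers are available for this series, and compound 3 carries the higher of them. Its nearest neighbour is compound 2, whose number lies lower by a gap that is beyond the scatter of repeat measurements, so compound 3 is the weaker of the two measured entries in this assay. Compound 1 contributes no number at all.

Compound 4, `C=CC(=O)Nc1ccc(-c2nc(Cl)cc(Nc3ccc(C(=O)Nc4cccc(C)c4)cc3)n2)cc1`, has not been measured. It differs from compound 3 in one place: hydrogen in place of methyl on an aromatic carbon. The change is the loss of a single carbon from the 2,5-dimethylphenyl group, giving the 3-methylphenyl group. Among the measured compounds shown here, no measured pair in this set shows the same change, so nothing here tells how large a step it brings, nor in which direction. The two measured numbers are both weak and lie within a modest gap of each other, which gives no reason to expect a large move. The step of a 1.3-fold lower number from compound 3 to compound 4 (0.12 log units; within the scatter) is expected to be small, most likely within the scatter. Compound 4 is thus estimated at 16000 nM, with a range from 5000 nM to 50000 nM.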

Compound 4, half-maximal inhibitory concentration: 6980 nM
For compound 4 the middle estimate is 2.3-fold (0.36 log units) above the measured one, and the stated range covers the measured number.
By their numbers in this assay, from the lowest: compounds 4 and 2 (each within the scatter of the next); then compound 3.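

Working from this assay, the series now has its first step between compounds that differ in one place: a 3.0-fold lower number from compound 3 to compound 4 (0.48 log units; beyond the scatter), with hydrogen in place of methyl on an aromatic carbon. The position ortho to a large group on the 2,5-dimethylphenyl group is therefore not silent in this assay, since losing that methyl gives a modest move towards stronger inhibition rather than one lost in the scatter. This is a single pair, so it marks out one position and one change and does not set a trend for the series. No measurement on hand accounts for the step.

Open, going by these compounds, is whether a fluorine, a methoxy group or an amine on that same carbon would shift the number in the same direction as hydrogen does, or whether a larger group such as an ethyl chain would reverse it. Also open, on these data alone, is whether replacing the remaining methyl of the 3-methylphenyl group with hydrogen would bring a further step of similar size, or none.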